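A few compounds are considered here, and "the series" means these few. Any claim that something is new, unique, unknown or untested is made for them only; others in the source may bear on it.

Compound 1 `Cc1cn([C@@H]2O[C@H](CO)[C@@H](CN)[C@H]2O)c(=O)[nH]c1=O` carries an aminomethyl group on the shared core. In a functional assay on P388 cells (Mus musculus) for antiproliferative activity, with a stated time of 72 h (a higher number here means that more compound is needed for the effect, a lower number that less compound is needed), compound 1 gives only a limit, > 100 uM. Compound 2 `Cc1cn([C@@H]2O[C@H](CO)[C@@H](CO)[C@H]2O)c(=O)[nH]c1=O` differs by hydroxy in place of amino on a saturated chain carbon bound to a saturated ring carbon. In this assay compound 2 likewise gives only a limit, > 100 uM. The step that the two limits leave unreadable from compound 1 to compound 2 therefore tells nothing about its size. Compound 3 `Cc1cn([C@H]2C[C@H](CN)[C@@H](CO)O2)c(=O)[nH]c1=O` has another core; the difference is hydrogen in place of hydroxy on a saturated ring carbon. In this assay compound 3 again gives only a limit, > 100 uM. The step that the two limits leave unreadable from compound 1 to compound 3 is equally uninformative. Going by the values given here, all values so far sit at the limit of > 100 uM in this assay, at which 3 of the 3 values shown sit. Compound 4 `Cc1cn([C@H]2C[C@H](CO)[C@@H](CO)O2)c(=O)[nH]c1=O`, not yet measured, repeats on the core of compound 3 the same change already seen between compound 1 and compound 2: hydroxy in place of amino on a saturated chain carbon bound to a saturated ring carbon. Because compound 3 sits at the limit of > 100 uM in this assay, at which 3 of the 3 values shown sit, and the earlier change left the value at the limit of > 100 uM in this assay, at which 3 of the 3 values shown sit, compound 4 is expected to give 150 uM, most likely again only a limit. The step that the limit leaves unreadable from compound 3 to compound 4 is expected to be small.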

Compound 4, concentration for half-maximal effect: 5 uM
The estimate for compound 4 lay 30-fold (1.48 log units) above the measured number; measured number outside the range, below it.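

In this assay, changing aminomethyl to hydroxymethyl on the core of compound 3 brings an at least 20-fold lower number from compound 3 to compound 4 (1.30 log units; beyond the scatter), and on the hydroxymethyl side, hydrogen in place of the ring hydroxy brings an at least 20-fold lower number from compound 2 to compound 4 (1.30 log units; beyond the scatter). Together these steps show that, of the compounds shown, only compound 4 gives a number rather than a limit, so the change has a large effect on this core when that hydrogen is present. They do not show how far the change carries from one core to another, since the same change on the core of compound 1 cannot be read, and neither can the other earlier steps: the limit of > 100 uM in this assay, at which 3 of the 4 values shown sit.

From the compounds shown here alone, whether a carboxylic acid in place of the hydroxymethyl of compound 4 would also give a measurable number stays open. The same question stands for a longer chain.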